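The source may report more compounds than this note shows. Statements on the series, on what has been measured and on what is new or still open speak of the compounds shown alone.

Compound 1 `COc1ccc(/C=C/C(=O)OCC(=O)Nc2ccccc2)cc1OC`: > 200000 nM
Compound 2 `COCOc1cc(/C=C/C(=O)OCC(=O)NCc2ccco2)ccc1OCc1ccccc1`: > 200000 nM
Compound 3 `CCOc1ccc(COc2c(OC)cc(/C=C/C(=O)OCC(=O)Nc3ccc(Cl)cc3)cc2OC)cc1`: > 200000 nM

Of the compounds shown here, three have been tested in a functional assay on CNE cells (Homo sapiens) for cytotoxicity, read by MTT assay, with a stated time of 72 h; on this read-out higher numbers stand for weaker inhibition and lower numbers for stronger inhibition. Compound 1 gives > 200000 nM, which is a limit of the assay and not a number. Compound 2 gives > 200000 nM, again a limit rather than a number. Compound 3 gives > 200000 nM, also a limit. Compound 2 therefore stands exactly where its two companions stand: no measured number separates any of them, as the limit of > 200000 nM in this assay, at which 3 of the 3 values shown sit, shows.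

Compound 4 `COCOc1cc(/C=C/C(=O)OCC(=O)Nc2ccc(Cl)cc2)ccc1OCc1ccccc1` has not yet been measured in this assay. It differs from compound 2 in a single place: 4-chlorophenyl in place of (furan-2-yl)methyl on an amide-type nitrogen. Among the measured compounds shown here, no step between two measured compounds is available to gauge this change, so no direction can be read from the data. For the measured compounds named here, the only guidance is that compound 3, which already carries the entering 4-chlorophenyl group on its amide-type nitrogen, sits at the same limit as the rest, per (the limit of > 200000 nM in this assay, at which 3 of the 3 values shown sit). The step from compound 2 to compound 4 is accordingly expected to be none beyond the scatter, estimated as a step that the limit leaves unreadable from compound 2 to compound 4. Compound 4 is expected to give 250000 nM, within 100000 nM to 1000000 nM, most likely reported once more only as a limit.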

Compound 4, half-maximal inhibitory concentration: > 200000 nM
Compound 4: no number, only a limit; the forecaster's own chance of this, stated with the estimate: 80%; the middle value does not contradict the limit.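

Compound 2 and compound 4 both sit at a limit rather than a number, so no step can be read between them: the limit of > 200000 nM in this assay, at which 4 of the 4 values shown sit.

The compounds shown leave open which change to the shared core, if any, would give a measurable number in this assay.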